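The source may report more compounds than this note shows. Statements on the series, on what has been measured and on what is new or still open speak of the compounds shown alone.

In a functional assay on MCF7 cells (Homo sapiens) for inhibition, read by MTT assay, with a stated time of 72 h (a lower number here means a stronger inhibitor, a higher number a weaker inhibitor), compound 1 `C=C(Br)C(=O)Nc1cccc(/C=C/C(=O)Nc2ccccc2)c1` gives 27300 nM, compound 2 `C=C(Br)C(=O)Nc1cccc(/C=C/C(=O)Nc2ccc(Cl)cc2)c1` gives 11000 nM, and compound 3 `C=C(Br)C(=O)Nc1cccc(/C=C/C(=O)Nc2ccc(OC)cc2)c1` gives 2500 nM, the lowest of the three numbers. Compound 4 `C=C(Br)C(=O)Nc1cccc(/C=C/C(=O)Nc2ccc(OCC)cc2)c1` differs from compound 3 by methyl in place of hydrogen on a saturated chain carbon bound to an oxygen on an aromatic ring, turning methoxy into ethoxy. Within the data shown here, no measured step makes this change. The closest evidence is the large step of an 11-fold lower number from compound 1 to compound 3 (1.04 log units; beyond the scatter), beside the modest steps of a 2.5-fold lower number from compound 1 to compound 2 (0.39 log units; beyond the scatter) and a 4.4-fold lower number from compound 2 to compound 3 (0.64 log units; beyond the scatter). These steps all replace a whole group on the aromatic ring, whereas this change only extends methoxy, so in this assay little or no step beyond the scatter is expected. The estimated step is a 1.0-fold higher number from compound 3 to compound 4 (0.02 log units; within the scatter). For compound 4 the expected value is 2600 nM, within an estimated range of 1000 nM to 6500 nM.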

Compound 4, half-maximal inhibitory concentration: 5500 nM
The estimate for compound 4 lay 2.1-fold (0.33 log units) below the measured number; low and high end bracket the measured number.
By their numbers in this assay, from the lowest: compound 3; then compounds 4 and 2 (each within the scatter of the next); then compound 1.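

In this assay the change from methoxy to ethoxy is not silent: one added methyl on the saturated chain carbon bound to an oxygen on an aromatic ring gives a step beyond the scatter (a 2.2-fold higher number from compound 3 to compound 4 (0.34 log units; beyond the scatter)), so this position is sensitive to small extensions. Ethoxy still stands clearly apart from hydrogen (a 5.0-fold lower number from compound 1 to compound 4 (0.70 log units; beyond the scatter)), while its step from chloro stays within the scatter (a 2.0-fold lower number from compound 2 to compound 4 (0.30 log units; within the scatter)). No measurement shown accounts for the effect of the added methyl.

Going by these compounds, whether a longer chain such as propoxy would continue this direction remains open. So does how a hydroxyl or an amine would compare with methoxy in the same place.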